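The source may report more compounds than this note shows. Statements on the series, on what has been measured and on what is new or still open speak of the compounds shown alone.

Measured in a functional assay on HL-60 cells (Homo sapiens) for antiproliferative activity, with a stated time of 72 h (a lower number here means a stronger inhibitor, a higher number a weaker inhibitor), are:
compound 1 (`OC[C@H]1O[C@@H](n2cnc3c(NCc4ccccc4F)ncnc32)[C@H](O)[C@@H]1O`) at 3200 nM
compound 2 (`OC[C@H]1O[C@@H](n2cnc3c(NCc4ccc(F)c(F)c4F)ncnc32)[C@H](O)[C@@H]1O`) at 13000 nM

Of these two, compound 2 carries the higher number, at 13000 nM and so is the weaker inhibitor. Compound 3 (`Cc1cccc(CNc2ncnc3c2ncn3[C@@H]2O[C@H](CO)[C@@H](O)[C@H]2O)c1O`) keeps the shared core and has 2-hydroxy-3-methylphenyl in place of 2,3,4-trifluorophenyl on a saturated chain carbon bound to a nitrogen on an aromatic ring. For the measured compounds named here, only one measured step bears on this change, a modest one at the same place (a 4.1-fold higher number from compound 1 to compound 2 (0.61 log units; beyond the scatter)). Going by the values given here, that step involves fluorinated groups only, and no measured compound has a hydroxy or methyl group there, so it is a loose guide. A modest move toward a lower number in this assay is expected, rather than a further rise. The expected step is a 3.3-fold lower number from compound 2 to compound 3 (0.51 log units; beyond the scatter) on this reading. Compound 3 is estimated at 4000 nM with wide uncertainty (expected range 1000 nM to 15000 nM).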

Compound 3, half-maximal inhibitory concentration: 15000 nM
Compound 3: the middle estimate sits 3.8-fold (0.57 log units) below what was measured; the range from low to high includes it.
By their numbers in this assay, from the lowest: compound 1; then compounds 2 and 3 (each within the scatter of the next).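

In this assay, 2-hydroxy-3-methylphenyl in place of 2,3,4-trifluorophenyl leaves the number within the scatter (a 1.2-fold higher number from compound 2 to compound 3 (0.06 log units; within the scatter)), so at this position a group without fluorine, carrying a hydrogen-bond donor and acceptor, gives a result that cannot be told apart from that of the trifluorinated group. The same group in place of 2-fluorophenyl gives a modest step (a 4.7-fold higher number from compound 1 to compound 3 (0.67 log units; beyond the scatter)), which leaves compound 1 as the strongest inhibitor of the three, with compound 2 and compound 3 level with each other. No measured information accounts for any of this.

Going by these compounds, the hydroxy and the methyl enter together in compound 3, so their separate contributions stay open. Also open, on these data alone, is whether an amine or a carboxylic acid on the phenyl ring would give a number nearer that of compound 1 or those of compound 2 and compound 3.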